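Hydroxyphenyl placement in a small inactive series

The source may hold more compounds than are shown below. What is called first, only, known or untested is meant among the compounds shown, and "the series" means these compounds.

Measured so far:
compound 1 `Oc1ccc(-c2cc(-c3cccc(F)c3)cc(-c3ccccc3O)n2)cc1`: > 50000 nM
compound 2 `Oc1ccc(-c2cc(-c3ccc(F)cc3)cc(-c3ccccc3O)n2)cc1`: > 50000 nM

In a functional assay on HeLa cells (Homo sapiens) for inhibition (on this read-out higher numbers stand for weaker inhibition and lower numbers for stronger inhibition), compound 1 gives > 50000 nM, which is a limit of the assay and not a number. In this assay compound 2 likewise gives > 50000 nM, again only a limit. For the measured compounds named here, compound 2 therefore stands at the edge of what this assay reports, with no number of its own, and all values so far sit at the limit of > 50000 nM in this assay, at which 2 of the 2 values shown sit. Going by the values given here, the single measured step, a step that the two limits leave unreadable from compound 1 to compound 2, is left unreadable by the two limits, so its size is unknown.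

Compound 3 `Oc1ccc(-c2cc(-c3ccc(F)cc3)cc(-c3ccc(O)cc3)n2)cc1` differs from compound 2 by 4-hydroxyphenyl in place of 2-hydroxyphenyl on an aromatic carbon. Among the compounds with values here, no measured step speaks to this change in a readable way, so no step beyond the scatter is expected in either direction in this assay. The estimated step that the limit leaves unreadable from compound 2 to compound 3 is set at no change. Compound 3 is expected at 80000 nM, within 20000 nM to 400000 nM, most likely reported again only as a limit.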

Compound 3, half-maximal inhibitory concentration: 8680 nM
For compound 3 the middle estimate is 9.2-fold (0.96 log units) above the measured one; measured number below the stated range.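

In this assay, for the compounds shown here, moving the hydroxyl around the ring at this position, next to the ring nitrogen, gives an at least 5.7-fold lower number from compound 2 to compound 3 (0.76 log units; beyond the scatter), the only readable step so far. Compound 2 and compound 3 have the same atoms, joined differently, so this position responds to where the hydroxyl sits on the phenyl ring and not merely to its presence, at least with 4-fluorophenyl elsewhere on the core. Compound 3 is also the only compound here with a number of its own, while the others remain at a limit: the limit of > 50000 nM in this assay, at which 2 of the 3 values shown sit.

Going by these compounds, it remains open whether 4-hydroxyphenyl at this position gives a similar step with 3-fluorophenyl in place of 4-fluorophenyl. The compounds shown also do not tell whether the hydroxyl itself is needed, which an amine or a carboxylic acid in its place on that phenyl ring would test.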